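The source may hold more compounds than are shown below. What is called first, only, known or untested is meant among the compounds shown, and "the series" means these compounds.

Among the compounds with values here, in a functional assay on HepG2 cells (Homo sapiens) for antiproliferative activity, read by MTT assay, with a stated time of 24 h (on this read-out lower numbers stand for stronger inhibition and higher numbers for weaker inhibition), compound 1 `C#CCOc1ccc2c(=O)c(-c3cc(OC)c(OC)cc3OC)coc2c1` gives 4950 nM, the only actual number among the three compounds measured. Compound 2 `COc1cccc(C(=O)Oc2ccc3c(=O)c(-c4cc(OC)c(OC)cc4OC)coc3c2)c1` reports only a limit, > 10000 nM. Compound 3 `COc1cc(OC)c(-c2coc3cc(OCC(=O)c4cccc(C(F)(F)F)c4)ccc3c2=O)cc1OC` also reports only a limit, > 10000 nM. Compound 4 `COc1cc(OC)c(-c2coc3cc(OCc4ccccc4F)ccc3c2=O)cc1OC` carries 2-fluorophenyl in place of ethynyl on a saturated chain carbon bound to an oxygen on an aromatic ring. Within the data shown here, two measured steps bear on this change, an at least 2.0-fold higher number from compound 1 to compound 2 (0.30 log units; that floor lies within the scatter) and an at least 2.0-fold higher number from compound 1 to compound 3 (0.30 log units; that floor lies within the scatter). Each brings in an aromatic ring, and each is only a floor that lies within the scatter, so neither fixes a size. The expected move in this assay is therefore modest and toward a higher number, estimated as a 1.6-fold higher number from compound 1 to compound 4 (0.21 log units; within the scatter). Compound 4 is expected at 8000 nM, with an estimated range of 3000 nM to 20000 nM.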

Compound 4, half-maximal inhibitory concentration: 1280 nM
Compound 4: the middle estimate sits 6.3-fold (0.80 log units) above what was measured; the whole stated range lies above it.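

In this assay, putting 2-fluorophenyl on a saturated chain carbon bound to an oxygen on an aromatic ring gives a 3.9-fold lower number from compound 1 to compound 4 (0.59 log units; beyond the scatter), so an added aromatic ring at this place need not raise the number. Against the two carbonyl-bearing compounds, the change gives an at least 7.8-fold lower number from compound 3 to compound 4 (0.89 log units; beyond the scatter) and an at least 7.8-fold lower number from compound 2 to compound 4 (0.89 log units; beyond the scatter). Those two steps are floors, each taken from a limit and not a number: the limit of > 10000 nM in this assay, at which 2 of the 4 values shown sit.

Going by these compounds, whether the fluorine or the benzyl ring itself carries the gain stays open, as does how an unsubstituted benzyl, an amine or a carboxylic acid would behave at this place.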